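The compounds below may be only part of what the source reports. "The series", "measured", "known", "first", "only" and "open" are said of these compounds alone.

Compound 3 `O=C(NCCCCc1ccccc1)c1cccc(C2SCC(=O)N2c2ccccc2)c1`, compound 1 `COc1ccc(C)cc1N1C(=O)CSC1c1cccc(C(=O)NCCCCc2ccccc2)c1` and compound 2 `COc1ccc(OC)c(N2C(=O)CSC2c2cccc(C(=O)NCCCCc3ccccc3)c2)c1` share one core and differ only in the ring on the amide-type nitrogen. In a functional assay on 143B cells (Homo sapiens) for inhibition, read by CCK-8 assay, with a stated time of 72 h, tested at 1 uM (on this read-out lower numbers stand for less inhibition and higher numbers for more inhibition at the one concentration tested (going by the name of the read-out)), compound 3 gives 60%, compound 1 gives 29% and compound 2 gives 2%, so compound 3 stands highest of the three. Compound 4 `Cc1cccc(N2C(=O)CSC2c2cccc(C(=O)NCCCCc3ccccc3)c2)c1` differs from compound 3 by methyl in place of hydrogen on an aromatic carbon. The measured steps that bear on this are a number 31 percentage points higher from compound 1 to compound 3 (beyond the scatter) and a number 58 percentage points higher from compound 2 to compound 3 (beyond the scatter), both showing that groups on that ring went with lower inhibition, while a number 27 percentage points lower from compound 1 to compound 2 (beyond the scatter) shows methoxy lowering the number further than methyl. A single methyl is therefore expected to lower inhibition only moderately, giving a number 15 percentage points lower from compound 3 to compound 4 (beyond the scatter). Compound 4 is estimated at 45%, with a range from 25% to 65%.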

Compound 4, a percentage reported as inhibition, at one concentration (the size of the read-out at that concentration, not a potency): 71%
For compound 4 the middle estimate is 26 percentage points below the measured one, and the stated range ends below it.
By their numbers in this assay, from the lowest: compound 2; then compound 1; then compound 3; then compound 4.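

Methyl in place of hydrogen at this place, meta to a large group, gives a number 11 percentage points higher from compound 3 to compound 4 (beyond the scatter), so a group on this ring need not lower inhibition. The earlier losses instead go with methoxy: with the methyl kept, hydrogen in place of methoxy gives a number 42 percentage points higher from compound 1 to compound 4 (beyond the scatter), and the wider ring change gives a number 69 percentage points higher from compound 2 to compound 4 (beyond the scatter). Nothing available explains why the methyl raises the number. Going by these compounds, whether an ethyl group, a longer chain or an amine at the same place would continue this rise remains open.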